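The source may report more compounds than this note shows. Statements on the series, on what has been measured and on what is new or still open speak of the compounds shown alone.

Working notes on the series, read in a functional assay on PC-3 cells (Homo sapiens) for cytotoxicity, read by MTT assay, with a stated time of 72 h; a lower number here means a stronger inhibitor, a higher number a weaker inhibitor. Compound 1 (`COc1ccc(OC)c(/C=C/C(=O)Nc2cc3c(Nc4ccc(F)c(Cl)c4)ncnc3cc2OC)c1`) gives 28600 nM, compound 2 (`O=C(/C=C/c1cccc(Cl)c1Cl)Nc1cc2c(Nc3ccc(F)c(Cl)c3)ncnc2cc1O[C@H]1CCOC1`) gives 27500 nM and compound 3 (`COc1ccc(OC)c(/C=C/C(=O)Nc2cc3c(Nc4ccc(F)c(Cl)c4)ncnc3cc2O[C@H]2CCOC2)c1`) gives 8730 nM. Compound 3 holds the lowest number of the three, and both others lie beyond the scatter from it.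

The next structure is compound 4 (`COc1cc(/C=C/C(=O)Nc2cc3c(Nc4ccc(F)c(Cl)c4)ncnc3cc2O[C@H]2CCOC2)cc(OC)c1O`), with 4-hydroxy-3,5-dimethoxyphenyl in place of 2,5-dimethoxyphenyl on a double-bonded chain carbon bound to a double-bonded chain carbon.

The measured step at this same place is a 3.2-fold lower number from compound 2 to compound 3 (0.50 log units; beyond the scatter), with 2,5-dimethoxyphenyl in place of 2,3-dichlorophenyl. The other step, a 3.3-fold lower number from compound 1 to compound 3 (0.52 log units; beyond the scatter), has oxolan-3-yl in place of methyl on an oxygen on an aromatic ring; that group stays unchanged in compound 4, so this step bears only indirectly. Among the measured compounds shown here, the series holds no measured compound with a hydroxy group at the changed place, and one modest step gives no firm direction. In this assay, a shift no larger than that modest step is expected, most likely within the scatter and leaning slightly towards a higher number. The estimated step is a 1.3-fold higher number from compound 3 to compound 4 (0.10 log units; within the scatter). For compound 4 the estimate is 11000 nM, with an expected range from 3500 nM to 32000 nM.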

Compound 4, half-maximal inhibitory concentration: 26500 nM
Estimate against measurement, compound 4: 2.4-fold (0.38 log units) below, and the stated range covers the measured number.
By their numbers in this assay, from the lowest: compound 3; then compounds 4, 2 and 1 (each within the scatter of the next).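

In this assay the place on a double-bonded chain carbon bound to a double-bonded chain carbon responds to the substitution pattern of the ring, not just to the presence of methoxy groups: 4-hydroxy-3,5-dimethoxyphenyl in place of 2,5-dimethoxyphenyl gives a 3.0-fold higher number from compound 3 to compound 4 (0.48 log units; beyond the scatter), about the size of the earlier step of a 3.2-fold lower number from compound 2 to compound 3 (0.50 log units; beyond the scatter) but in the opposite direction. Set against 2,3-dichlorophenyl, the same group gives a 1.0-fold lower number from compound 2 to compound 4 (0.02 log units; within the scatter), so these two differently substituted rings read alike, and among the three rings at this place only the 2,5-dimethoxyphenyl of compound 3 stands apart. Nothing measured here offers an explanation for these steps.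

The change from compound 3 to compound 4 adds a hydroxy group and rearranges the methoxy groups in one move, so the shown compounds cannot assign the step to either part. Also open, from the compounds shown here alone, is how a plain phenyl, or a ring carrying an amine or a carboxylic acid, would read at this place, and whether the step from methyl to oxolan-3-yl on the oxygen holds with 4-hydroxy-3,5-dimethoxyphenyl in place.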